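Methoxy enters para to a large group

The source may report more compounds than this note shows. Statements on the series, on what has been measured and on what is new or still open speak of the compounds shown alone.

For the measured compounds named here, compound 2 `C/C(=C\COc1ccccc1)CC/C=C(\C)C1=CC(=O)C(C)(C)O1` gives 35.2 ug/mL in a functional assay (Homo sapiens) for inhibition (a lower number here means a stronger inhibitor, a higher number a weaker inhibitor), the lower of the two numbers known, with compound 1 `COc1cccc(OC/C=C(\C)CC/C=C(\C)C2=CC(=O)C(C)(C)O2)c1` nearest at 35.9 ug/mL. Compound 3 `COc1ccc(OC/C=C(\C)CC/C=C(\C)C2=CC(=O)C(C)(C)O2)cc1` differs from compound 2 by methoxy in place of hydrogen on an aromatic carbon. Going by the values given here, the only step that bears on this is a 1.0-fold lower number from compound 1 to compound 2 (0.01 log units; within the scatter), where a methoxy on an aromatic carbon was removed without effect beyond the scatter. Among the compounds with values here, no step at the place para to a large group is known. Compound 3 is therefore expected to change little, as a 1.0-fold lower number from compound 2 to compound 3 (0.00 log units; within the scatter), with an estimate of 35 ug/mL and a range from 18 ug/mL to 70 ug/mL.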

Compound 3, half-maximal inhibitory concentration: 38.6 ug/mL
For compound 3 the middle estimate is 1.1-fold (0.04 log units) below the measured one, within the range that was stated.
By their numbers in this assay, from the lowest: compounds 2, 1 and 3 (each within the scatter of the next).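

At the place para to a large group, the change from phenyl to 4-methoxyphenyl gives a 1.1-fold higher number from compound 2 to compound 3 (0.04 log units; within the scatter) and so has no effect beyond the scatter. Shifting the methoxy, as 4-methoxyphenyl in place of 3-methoxyphenyl, gives a 1.1-fold higher number from compound 1 to compound 3 (0.03 log units; within the scatter), so the two placements of the group cannot be told apart in this measurement. Nothing available explains why these numbers stay so close.

The compounds shown leave open whether an amine or a carboxylic acid at this place would move the number. As far as these compounds go, it also remains open whether a longer chain on the oxygen, such as butoxy, would do so.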